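A few compounds are considered here, and "the series" means these few. Any claim that something is new, unique, unknown or untested is made for them only; others in the source may bear on it.

Measured in a functional assay on A2780 cells (Homo sapiens) for cytotoxicity, read by MTT assay, with a stated time of 72 h; a lower number here means a stronger inhibitor, a higher number a weaker inhibitor:
- compound 1 `O=C(CCCCCN(CC(=O)NC1CCCCC1)C(=O)c1ccccc1)NO` gives 3460 nM
- compound 2 `CN(C)c1ccc(C(=O)N(CCCCCC(=O)NO)CC(=O)NC2CCCCC2)cc1` gives 1540 nM
- compound 3 `Cc1cc(C)cc(C(=O)N(CCCCCC(=O)NO)CC(=O)NC2CCCCC2)c1` gives 160 nM

Compound 1, at 3460 nM in this assay, has the highest number of the three and is the weakest inhibitor among them. Compound 4 `CC(C)(C)NC(=O)CN(CCCCCC(=O)NO)C(=O)c1ccccc1` is still to be measured. It keeps the core of compound 1 but carries tert-butyl in place of cyclohexyl on an amide-type nitrogen, a change counted as follows: tert-butyl in place of cyclohexyl on an amide-type nitrogen.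

Three measured steps are available, and none of them touches this group. The change on the phenyl ring gives a 2.2-fold lower number from compound 1 to compound 2 (0.35 log units; beyond the scatter), the larger one gives a 22-fold lower number from compound 1 to compound 3 (1.33 log units; beyond the scatter), and the swap between the two substituted rings gives a 9.6-fold lower number from compound 2 to compound 3 (0.98 log units; beyond the scatter). These steps show that the numbers in this small set can move considerably when the benzoyl side is altered, but they say nothing directly about the cyclohexyl side. The data therefore offer no reason to expect a step beyond the scatter in either direction, although the uncertainty remains wide. The expected result is a 1.2-fold lower number from compound 1 to compound 4 (0.06 log units; within the scatter), an estimate that stays within the scatter. Compound 4 is expected at 3000 nM, with an estimated range from 1000 nM to 9000 nM, when it is measured.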

Compound 4, half-maximal inhibitory concentration: 20700 nM
For compound 4 the middle estimate is 6.9-fold (0.84 log units) below the measured one; the measured number lies above the stated range.
By their numbers in this assay, from the lowest: compound 3; then compound 2; then compound 1; then compound 4.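

Read in this assay, tert-butyl in place of cyclohexyl on the amide-type nitrogen gives a 6.0-fold higher number from compound 1 to compound 4 (0.78 log units; beyond the scatter) and thus shows that this side of the molecule, untouched by the earlier steps, also moves the number beyond the scatter, here toward a weaker inhibitor. Cyclohexyl and tert-butyl match in their counts of hydrogen-bond donors, hydrogen-bond acceptors and net charge, so the counted difference is confined to the loss of the six-membered carbon ring and the drop from 6 heavy atoms to 4 heavy atoms. No measurement is available that would explain the change in this number.

Still open, going by these compounds, is whether the ring itself or the carbon count matters more on this nitrogen, a question that cyclopentyl, phenyl or an open hexyl chain at the same place could help to separate. On these data alone, it is also open whether the gain seen in a 22-fold lower number from compound 1 to compound 3 (1.33 log units; beyond the scatter) would carry over to a compound pairing the 3,5-dimethylphenyl group with tert-butyl on the amide-type nitrogen.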